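Methanesulfonamido in place of pyrrolidin-1-yl: working notes

This account rests on a few compounds, and the source may have more. Where it says the series, first, only, none or still open, it means among the compounds named here.

- compound 1 `O=C(Nc1ccc(O)c2c(=O)cc(-c3ccccc3Cl)oc12)c1ccc(Cl)cc1`: 4600 nM
- compound 2 `O=c1cc(-c2ccccc2Cl)oc2c(N3CCCC3)ccc(O)c12`: 20000 nM

In a functional assay on MCF7 cells (Homo sapiens) for antiproliferative activity (a higher number here means a weaker inhibitor, a lower number a stronger inhibitor), compound 2 holds the higher of the two numbers, and compound 1 lies lower by a gap beyond the scatter. Compound 3 `CS(=O)(=O)Nc1ccc(O)c2c(=O)cc(-c3ccccc3Cl)oc12` has not yet been measured. It carries methanesulfonamido in place of pyrrolidin-1-yl on an aromatic carbon, para to a hydroxy group methanesulfonamido in place of pyrrolidin-1-yl on an aromatic carbon and keeps the rest of the shared core.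

Going by the values given here, no step in one place links the two measured compounds, so any expectation rests on thin ground. The nearest guide is compound 1 (4600 nM), which, like compound 3, has a hydrogen on the nitrogen at that carbon. Two values cannot show whether that feature matters. In this assay a moderate shift toward a lower number, perhaps only just beyond the scatter, is expected for the step of a 2.2-fold lower number from compound 2 to compound 3 (0.35 log units; beyond the scatter) and should be read as tentative. The estimate for compound 3 is 9000 nM within an expected range of 3000 nM to 25000 nM pending measurement.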

Compound 3, half-maximal inhibitory concentration: 25000 nM
Beside the measured number, compound 3's estimate is 2.8-fold (0.44 log units) below it; the measured number falls inside the stated range.
By their numbers in this assay, from the lowest: compound 1; then compounds 2 and 3 (each within the scatter of the next).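

In this assay, methanesulfonamido in place of pyrrolidin-1-yl gives a 1.3-fold higher number from compound 2 to compound 3 (0.10 log units; within the scatter), so at this aromatic carbon, para to a hydroxy group, this exchange of two groups of equal heavy-atom count, one with a hydrogen-bond donor and one without, does not separate the compounds. With the nitrogen kept, methylsulfonyl in place of (4-chlorophenyl)carbonyl gives a 5.4-fold higher number from compound 1 to compound 3 (0.74 log units; beyond the scatter), which shows that a hydrogen on this nitrogen does not by itself go with the lower number of compound 1, and that the group carried on the nitrogen can shift the value in this series. No accompanying data bear on why these two steps differ in size.

Which part of (4-chlorophenyl)carbonyl goes with the lower number of compound 1 remains open, as the aryl ring, its chlorine and the carbonyl all change together in the step from compound 1 to compound 3. An unsubstituted benzoyl group or an acetyl group on the same nitrogen, or a 4-chlorobenzenesulfonyl group, would begin to separate these parts.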